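A few compounds are considered here, and "the series" means these few. Any claim that something is new, unique, unknown or untested is made for them only; others in the source may bear on it.

Compound 1 `CCC(C)[C@H](NC(=O)Cc1c(C)n(C(=O)c2ccc(Cl)cc2)c2ccc(OC)cc12)C(=O)NS(=O)(=O)c1ccc(Cl)c([N+](=O)[O-])c1` sets the reference: in an assay on isolated protein for binding affinity to Apoptosis regulator Bcl-2 (Homo sapiens), read by fluorescence polarization (a higher number here means a weaker inhibitor, a lower number a stronger inhibitor), compound 1 gives 4900 nM. Compound 2 `COc1ccc2c(c1)c(CC(=O)N[C@@H](CC(C)C)C(=O)NS(=O)(=O)c1ccc(Cl)c([N+](=O)[O-])c1)c(C)n2C(=O)c1ccc(Cl)cc1` carries an isobutyl in place of the sec-butyl. In this assay compound 2 gives > 5000 nM, which is a limit of the assay and not a number. Compound 2 thus sits at the limit of > 5000 nM in this assay, at which 1 of the 2 values shown sits. Compound 3 `COc1ccc2c(c1)c(CC(=O)N[C@@H](CCSC)C(=O)NS(=O)(=O)c1ccc(Cl)c([N+](=O)[O-])c1)c(C)n2C(=O)c1ccc(Cl)cc1` differs from compound 2 by (methylsulfanyl)methyl in place of isopropyl on a saturated chain carbon, two bonds along the chain from an amide-type nitrogen and a carbonyl carbon. Going by the values given here, only one measured step bears on such a side-chain swap, an at least 1.0-fold higher number from compound 1 to compound 2 (0.00 log units; that floor lies within the scatter), which stayed within the scatter, so no shift beyond the scatter is expected in this assay and another limit is likely. Compound 3 is therefore estimated at 6000 nM, within 3000 nM to 15000 nM, the expected step being a step that the limit leaves unreadable from compound 2 to compound 3.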

Compound 3, inhibition constant: > 5000 nM
Compound 3: only a limit was reported; the forecaster's own chance of this, stated with the estimate: 60%; the middle value does not contradict the limit.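

Compound 3 also gives only a limit of the assay in this assay, so a sulfur-bearing chain at this position joins isobutyl there: the limit of > 5000 nM in this assay, at which 2 of the 3 values shown sit. Replacing sec-butyl with 2-(methylsulfanyl)ethyl gives an at least 1.0-fold higher number from compound 1 to compound 3 (0.00 log units; that floor lies within the scatter). The step between the two limits of compound 2 and compound 3 cannot be read.

From the compounds shown here alone, how far either compound lies past its limit remains open. So does whether an amine or a carboxylic acid on this side chain would give a clearly lower number than compound 1 at 4900 nM.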